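This account rests on a few compounds, and the source may have more. Where it says the series, first, only, none or still open, it means among the compounds named here.

Series notes, measured in an ADME assay on MRC5 cells (Homo sapiens) for cytotoxicity, read by MTT assay, with a stated time of 24 h; a higher number here means that more compound is tolerated, a lower number that less compound is tolerated:

- compound 1 `CC1(C)[C@H]2CC[C@]1(C)N(Cc1cn(-c3ccccc3C#N)nn1)C(=O)C2`: 23300 nM
- compound 2 `CC1(C)[C@H]2CC[C@]1(C)N(Cc1cn(-c3ccccc3F)nn1)C(=O)C2`: 15100 nM
- compound 3 `CC1(C)[C@H]2CC[C@]1(C)N(Cc1cn(-c3ccccc3Cl)nn1)C(=O)C2`: 4130 nM

Compound 3 has the lowest of the three numbers. The two steps that reach it, a 3.7-fold lower number from compound 2 to compound 3 (0.56 log units; beyond the scatter) and a 5.6-fold lower number from compound 1 to compound 3 (0.75 log units; beyond the scatter), both lie beyond the scatter, whereas a 1.5-fold lower number from compound 1 to compound 2 (0.19 log units; within the scatter) stays within it.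

The next compound is compound 4 `CC1(C)[C@H]2CC[C@]1(C)N(Cc1cn(-c3ccccc3)nn1)C(=O)C2`, which has hydrogen in place of chloro on an aromatic carbon, ortho to a large group, so that 2-chlorophenyl becomes phenyl: hydrogen in place of chloro on an aromatic carbon.

Among the compounds with values here, no measured compound carries hydrogen at this place, so the evidence is indirect. All three measured steps change the group at this same aromatic carbon. The two that bear most directly are those that end on chloro, a 3.7-fold lower number from compound 2 to compound 3 (0.56 log units; beyond the scatter) and a 5.6-fold lower number from compound 1 to compound 3 (0.75 log units; beyond the scatter), both modest. Each of them shows chloro with a lower number than the group it replaces, though neither group is hydrogen.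

In this assay, a modest move to a higher number is therefore expected on losing chloro, close in size to the gap between compound 3 and compound 2. The expected change is a 3.1-fold higher number from compound 3 to compound 4 (0.50 log units; beyond the scatter). Compound 4 is estimated at 13000 nM, with an expected range from 5500 nM to 30000 nM.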

Compound 4, half-maximal cytotoxic concentration: 9730 nM
For compound 4 the middle estimate is 1.3-fold (0.13 log units) above the measured one; the range from low to high includes it.
By their numbers in this assay, from the lowest: compound 3; then compounds 4, 2 and 1 (each within the scatter of the next, the first and the last beyond it).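

In this assay, hydrogen gives this aromatic carbon, ortho to a large group, its first plain reference point: the step from 2-chlorophenyl to phenyl (a 2.4-fold higher number from compound 3 to compound 4 (0.37 log units; beyond the scatter)) shows that chloro sits lower than hydrogen too, not only lower than fluoro and nitrile. Fluoro and hydrogen cannot be told apart (a 1.6-fold lower number from compound 2 to compound 4 (0.19 log units; within the scatter)), whereas nitrile stands clear of hydrogen (a 2.4-fold lower number from compound 1 to compound 4 (0.38 log units; beyond the scatter)), although nitrile and fluoro themselves lie within the scatter of each other (a 1.5-fold lower number from compound 1 to compound 2 (0.19 log units; within the scatter)). Chloro alone is thus set apart from all three other groups at this place, while those three do not fall into separate levels, with only the outer pair, nitrile and hydrogen, beyond the scatter. Nothing at hand speaks to the reason for these differences.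

The compounds shown leave open whether bromo or methyl at this aromatic carbon would give a number near that of chloro, and where an amine or a carboxylic acid would fall. They also leave open whether chloro lowers the number at any other carbon of the phenyl ring, with only this one place varied here.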